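Cyclopropyl in place of 1H-benzimidazol-2-yl

The compounds below may be only part of what the source reports. "The series", "measured", "known", "first", "only" and "open" are said of these compounds alone.

In a functional assay on MCF7 cells (Homo sapiens) for inhibition, read by MTT assay, with a stated time of 72 h (on this read-out higher numbers stand for weaker inhibition and lower numbers for stronger inhibition), compound 3 `Cc1cc(Nc2cc(-c3ccccc3)[nH]n2)n2nc(SCc3nc4ccccc4[nH]3)nc2n1` gives 2730 nM and compound 2 `Cc1cc(Nc2cc(-c3ccccc3)[nH]n2)n2nc(SCC(=O)c3ccccc3)nc2n1` gives 5240 nM. These two numbers are not separated, with a 1.9-fold lower number from compound 2 to compound 3 (0.28 log units; within the scatter). Compound 1 `Cc1cc(Nc2cc(-c3ccccc3)[nH]n2)n2nc(SCC3CCCCC3)nc2n1` reads > 50000 nM, which is a limit of the assay and not a number.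

Compound 4 `Cc1cc(Nc2cc(-c3ccccc3)[nH]n2)n2nc(SCC3CC3)nc2n1` differs from compound 3 by cyclopropyl in place of 1H-benzimidazol-2-yl on a saturated chain carbon bound to a sulfur. Going by the values given here, the closest precedent is compound 1, which carries cyclohexyl at that place. Among the compounds with values here, two steps bear on the change: an at least 18-fold lower number from compound 1 to compound 3 (1.26 log units; beyond the scatter) and an at least 9.5-fold lower number from compound 1 to compound 2 (0.97 log units; beyond the scatter). Both start from a limit, so their true sizes are open. Among these three compounds, the non-aromatic carbon ring gives the highest reading, and no compound goes against that. Compound 4 is therefore expected to move away from compound 3 toward weaker inhibition, though it may stop short of the limit. The expected change is a 7.3-fold higher number from compound 3 to compound 4 (0.86 log units; beyond the scatter). For compound 4 the estimated value is 20000 nM, with an expected range of 6000 nM to 50000 nM.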

Compound 4, half-maximal inhibitory concentration: > 50000 nM
Compound 4 ended at the assay's limit (the forecaster's own chance of this, stated with the estimate: 35%); middle value at least 2.5-fold (0.39 log units) away from the limit.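

In this assay, the three-membered cyclopropyl ring on a saturated chain carbon bound to a sulfur gives a limit and not a number, as the cyclohexyl ring of compound 1 does, so among the compounds shown, both non-aromatic carbon rings at this place read at the limit, and none goes against that. The change costs an at least 18-fold higher number from compound 3 to compound 4 (1.26 log units; beyond the scatter) and an at least 9.5-fold higher number from compound 2 to compound 4 (0.97 log units; beyond the scatter), so the loss seen with cyclohexyl does not depend on that ring's size. The step between compound 1 and compound 4 cannot be read, because both sit at the limit: the limit of > 50000 nM in this assay, at which 2 of the 4 values shown sit.

Going by these compounds, whether a plain phenyl ring, an amine or a longer alkyl chain on that carbon would read like benzoyl or like cyclopropyl stays open. On these data alone, the true distance of compound 1 and compound 4 from the other two compounds also stays open.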